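Replacing the 3-ureidopropyl group: compound 2 to compound 3

This account rests on a few compounds, and the source may have more. Where it says the series, first, only, none or still open, it means among the compounds named here.

In an ADME assay on microsomes from liver (Homo sapiens) for metabolic stability, using NADPH, with a stated time of 10 min (a higher number here means that more of the compound is left, a lower number that less of the compound is left), compound 1 `NCCCCN(C[C@H]1Cc2ncccc2CN1)[C@H]1CCCc2cccnc21` gives 100% and compound 2 `NC(=O)NCCCCN(C[C@H]1Cc2ncccc2CN1)[C@H]1CCCc2cccnc21` gives 91%, the two lying within the scatter of each other. Compound 3 `NC(=O)NC/C=C\CN(C[C@H]1Cc2ncccc2CN1)[C@H]1CCCc2cccnc21`, not yet measured, differs from compound 2 by a group of 7 heavy atoms (4 carbon, 2 nitrogen, 1 oxygen; no ring) in place of a group of 7 heavy atoms (4 carbon, 2 nitrogen, 1 oxygen; no ring), on a saturated chain carbon bound to an amine nitrogen; the 3-ureidopropyl group leaves. Going by the values given here, the only measured step, a number 9 percentage points lower from compound 1 to compound 2 (within the scatter), is a different change and stays within the scatter, so it offers weak guidance. No shift beyond the scatter in this assay is expected, at most a small downward drift. The estimated step is a number 5 percentage points lower from compound 2 to compound 3 (within the scatter). For compound 3 the expected value is 86%, with an estimated range of 66% to 100%.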

Compound 3, percent of the compound remaining: 100%
Compound 3: middle estimate off by 14 percentage points, on the low side; the measured number falls inside the stated range.
By their numbers in this assay, from the lowest: compounds 2, 1 and 3 (each within the scatter of the next).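

In this assay, the group with a second double bond outside aromatic rings, in place of the 3-ureidopropyl group, gives a number 9 percentage points higher from compound 2 to compound 3 (within the scatter). Set against the shorter group of compound 1, it gives no change at the digits printed from compound 1 to compound 3 (within the scatter), so neither step at this saturated chain carbon bound to an amine nitrogen goes beyond the scatter, and the read-out does not rank the three compounds. No data at hand bear on the reason for this result. From the compounds shown here alone, whether a carboxylic acid or a longer chain in place of this group would also stay within the scatter remains open.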